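The source may hold more compounds than are shown below. What is called first, only, known or untested is meant among the compounds shown, and "the series" means these compounds.

Measured in a physicochemical assay for solubility, read by HPLC, using the shake flask method, in phosphate buffer, with a stated time of 20 h, at pH 6.5; on this read-out lower numbers stand for lower solubility and higher numbers for higher solubility:

- Compound 1 `Fc1ccc(-c2nc3c(N4CCNCC4)nccc3[nH]2)cc1F`: 150000 nM
- Compound 2 `Fc1ccc(-c2nc3c(N4CCCNCC4)nccc3[nH]2)cc1F`: 165000 nM
- Compound 3 `NC1CCN(c2nccc3[nH]c(-c4ccc(F)c(F)c4)nc23)CC1`: 200000 nM

These three numbers cannot be told apart. Compound 3 has the highest number, but the gaps to the other two are small: a 1.2-fold higher number from compound 2 to compound 3 (0.08 log units; within the scatter) and a 1.3-fold higher number from compound 1 to compound 3 (0.12 log units; within the scatter).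

Compound 4 `CN1CCN(C(=O)C2CCN(c3nccc4[nH]c(-c5ccc(F)c(F)c5)nc34)CC2)CC1` keeps the rest of compound 3 but carries (4-methylpiperazin-1-yl)carbonyl in place of amino on a saturated ring carbon.

The measured steps offer only loose guidance. The three are a 1.1-fold higher number from compound 1 to compound 2 (0.04 log units; within the scatter), a 1.3-fold higher number from compound 1 to compound 3 (0.12 log units; within the scatter) and a 1.2-fold higher number from compound 2 to compound 3 (0.08 log units; within the scatter). Each swaps a group on an aromatic carbon, and none changes the saturated ring carbon altered here. Still, all three stayed within the scatter, so no clear shift is expected in this assay, although the uncertainty is wide. The estimated step is a 1.3-fold lower number from compound 3 to compound 4 (0.12 log units; within the scatter). For compound 4, the expected value is 150000 nM, within an estimated range of 50000 nM to 350000 nM.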

Compound 4, solubility: 200000 nM
For compound 4 the middle estimate is 1.3-fold (0.12 log units) below the measured one; the range from low to high includes it.
By their numbers in this assay, from the lowest: compounds 1, 2, 3 and 4 (each within the scatter of the next).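

In this assay, among the compounds shown here, the earlier steps only swapped groups on an aromatic carbon, so this is the first reading at a saturated ring carbon, and the swap there gives no change at the digits printed from compound 3 to compound 4 (within the scatter) with the rest of the molecule kept the same. The swap is a large one by count: amino, with 1 heavy atom and 1 hydrogen-bond donor, leaves, while (4-methylpiperazin-1-yl)carbonyl, with 9 heavy atoms, a six-membered non-aromatic ring and 0 hydrogen-bond donors, enters. No supporting measurement bears on why the read-out holds steady through so large a swap.

Open, from the compounds shown here alone, is how a carboxylic acid or a plain ethyl chain would behave on this same saturated ring carbon. With only amino and (4-methylpiperazin-1-yl)carbonyl shown there, the compounds cannot say whether any group at this position would leave the read-out unmoved.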